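Cytotoxicity notes on a quinoline amine series

The source may hold more compounds than are shown below. What is called first, only, known or untested is meant among the compounds shown, and "the series" means these compounds.

Of the compounds shown here, two have been measured in an ADME assay on HEp-2 cells (Homo sapiens) for cytotoxicity, read by CCK-8 assay, with a stated time of 5 days; on this read-out higher numbers stand for lower toxicity in this test and lower numbers for higher toxicity in this test. Compound 1 `NCCCCNc1cc(N2CCc3ccccc3C2)nc2ccccc12` gives 7400 nM in this assay. Compound 2 `CNCCNc1cc(N2CCCc3ccc(F)cc3C2)nc2ccc(C)cc12` gives 29000 nM in this assay, the highest of the two numbers; its gap to compound 1 lies beyond the usual scatter of the measurement, so compound 2 is the less toxic of the two.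

The next step leads from compound 2 to compound 3 `Cc1ccc2nc(N3CCCc4ccc(F)cc4C3)cc(NC(=O)CN)c2c1`. The two differ in one place: (aminomethyl)carbonyl in place of 2-(methylamino)ethyl on a nitrogen on an aromatic ring. For the measured compounds named here, no pair of measured compounds shows this change, so there is no measured step to lean on. The side chain that leaves and the one that enters are of the same size, and the expectation is a step no larger than the scatter, with no clear direction, as in a 1.0-fold higher number from compound 2 to compound 3 (0.01 log units; within the scatter). In this assay compound 3 is expected at 30000 nM, within a range from 10000 nM to 90000 nM.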

Compound 3, half-maximal cytotoxic concentration: > 100000 nM
Compound 3: a limit, no number (the forecaster's own chance of this, stated with the estimate: 20%); middle value at least 3.3-fold (0.52 log units) from the limit.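

In this assay compound 3 gives > 100000 nM, a limit of the assay and not a number. The earlier compounds shown here held no single-place change at this site, on a nitrogen on an aromatic ring; here, (aminomethyl)carbonyl in place of 2-(methylamino)ethyl gives an at least 3.4-fold higher number from compound 2 to compound 3 (0.53 log units; beyond the scatter), so a swap with no change in heavy-atom count still moves the read-out toward lower toxicity in this test. The full size of this step cannot be read because compound 3 stands at the limit: the limit of > 100000 nM in this assay, at which 1 of the 3 values shown sits.

The step changes the carbonyl and the chain end together, and the compounds shown do not separate the two. Also open, going by these compounds, is how a longer chain on the same carbonyl, ending in a dimethylamino group, would read at this nitrogen.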